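A few compounds are considered here, and "the series" means these few. Any claim that something is new, unique, unknown or untested is made for them only; others in the source may bear on it.

Of the compounds shown here, three built on one shared core have been tested in a functional assay on HepG2 cells (Homo sapiens) for cytotoxicity, read by MTT assay, with a stated time of 48 h; a higher number here means a weaker inhibitor, a lower number a stronger inhibitor. Compound 1 `COc1ccc(Nc2n[n+]([O-])c3ccccc3[n+]2[O-])cc1` gives 10100 nM. Compound 2 `CCCCCCCCNc1n[n+]([O-])c2ccccc2[n+]1[O-]` gives 17400 nM, and compound 3 `[O-][n+]1nc(NC2CC2)[n+]([O-])c2ccccc21` gives 13300 nM. Compound 1 shows the lowest of the three numbers, yet its gaps to compound 3 and to compound 2 both lie within the usual scatter, so the three cannot be told apart. Compound 4 `Cc1ccc(Nc2n[n+]([O-])c3ccccc3[n+]2[O-])cc1` is the next to be measured in this assay. It differs from compound 1 in a single place: methyl in place of methoxy on an aromatic carbon. Going by the values given here, no step between measured compounds is available to gauge such a change, so the expected step of a 1.0-fold lower number from compound 1 to compound 4 (0.00 log units; within the scatter) is small, none beyond the scatter. Compound 4 is therefore estimated at 10000 nM, with a range from 5000 nM to 25000 nM.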

Compound 4, half-maximal inhibitory concentration: 10600 nM
Compound 4: the middle estimate sits 1.1-fold (0.03 log units) below what was measured, and the stated range covers the measured number.
By their numbers in this assay, from the lowest: compounds 1, 4, 3 and 2 (each within the scatter of the next).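

Methyl in place of methoxy on this aromatic carbon, para to a large group, gives a 1.0-fold higher number from compound 1 to compound 4 (0.02 log units; within the scatter) in this assay and so makes no readable difference. Going by these compounds alone, this is the first one-place change, and it shows that this assay does not separate the two groups at this position, even though methoxy carries an oxygen and a hydrogen-bond acceptor that methyl lacks. No measurement at hand explains why the two groups read alike.

From the compounds shown here alone, whether an amine or a carboxylic acid at this position would move the number beyond the scatter remains open. So does the effect of a longer chain, such as ethoxy.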